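Working notes: replacing hydroxy on the shared core

The source may report more compounds than this note shows. Statements on the series, on what has been measured and on what is new or still open speak of the compounds shown alone.

Measured compounds:
compound 1 `CCOC(=O)C(=O)Nc1ccc(O)c(=O)cc1`: 10%
compound 2 `CCOC(=O)C(=O)Nc1ccccc(Oc2ccccc2)c1=O`: 16%
compound 3 `CCOC(=O)C(=O)Nc1ccccc(Br)c1=O`: 52%

In a functional assay on the whole organism (strain Sprague-Dawley CD) for inhibition, with Rattus norvegicus as the target, read by paw edema, at a dose of 30 mg/kg by the intraperitoneal route (a higher number here means a stronger effect of the compound at the dose given, a lower number a weaker effect), compound 1 gives 10%, the lowest of the three numbers, though its gap to compound 2 lies within the scatter; compound 3 stands beyond the scatter above it. For the measured compounds named here, the one step between measured compounds, a number 36 percentage points higher from compound 2 to compound 3 (beyond the scatter), is a bromo-for-phenoxy exchange at a different place on the core and does not bear on the change now considered.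

The next compound is compound 4 `CCOC(=O)C(=O)Nc1ccc(NC(=O)C(=O)OCC)c(=O)cc1`. It differs from compound 1 by ((ethoxycarbonyl)carbonyl)amino in place of hydroxy on an aromatic carbon. Going by the values given here, no measured pair shows what this exchange does to paw edema inhibition, and the measured step concerns another position, so the expectation rests on compound 1 alone. The estimated step is a number 5 percentage points higher from compound 1 to compound 4 (within the scatter), with no change beyond the scatter expected. For compound 4 the value expected in this assay is 15%, with a range from 0% to 35%.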

Compound 4, a percentage reported as inhibition, in the whole organism at one dose (the size of the read-out at that dose, not a potency): 84%
Beside the measured number, compound 4's estimate is 69 percentage points below it; measured number above the stated range.
By their numbers in this assay, from the lowest: compounds 1 and 2 (each within the scatter of the next); then compound 3; then compound 4.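

This position on the shared core is not indifferent to substitution: ((ethoxycarbonyl)carbonyl)amino in place of hydroxy on this aromatic carbon gives, in this assay, a number 74 percentage points higher from compound 1 to compound 4 (beyond the scatter), the first step measured at this place. The site therefore accepts a group of 8 heavy atoms in place of a single oxygen with a large rise in the read-out at this one dose, and compound 4 carries that group here as well as the one three ring bonds away. No measurement at hand accounts for this step.

The compounds shown leave open whether the whole entering group is needed or only part of it. A plain amine at this position, or the carboxylic acid in place of the ethyl ester, would separate those parts, and a longer chain would test how far the group can extend.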